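Compound 3 to compound 4: a step from the limit

The source may report more compounds than this note shows. Statements on the series, on what has been measured and on what is new or still open speak of the compounds shown alone.

In a physicochemical assay for solubility, in phosphate buffer, at pH 7.4 (a lower number here means a less soluble compound, a higher number a more soluble compound), compound 1 (`CCOC(=O)c1c(-c2ccc(OC)cc2)[nH]c2cccc(OC)c2c1=O`) gives > 100000 nM as a limit, not a number. Compound 2 (`CCOC(=O)c1c(-c2ccccc2Cl)[nH]c2cccc(OC)c2c1=O`) gives > 100000 nM as a limit too. Compound 3 (`CCOC(=O)c1c(-c2ccccc2C)[nH]c2cccc(OC)c2c1=O`) gives > 100000 nM as a limit as well, so it has no number of its own. Among the compounds with values here, the series so far shows the limit of > 100000 nM in this assay, at which 3 of the 3 values shown sit, and nothing more.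

Compound 4 (`CCOC(=O)c1c(-c2ccc(Cl)c(Cl)c2)[nH]c2cccc(OC)c2c1=O`) has 3,4-dichlorophenyl in place of 2-methylphenyl, on the aromatic carbon next to the ring nitrogen and ortho to an ethoxycarbonyl group (3,4-dichlorophenyl in place of 2-methylphenyl on an aromatic carbon).

Three measured steps change the group at that same carbon: a step that the two limits leave unreadable from compound 1 to compound 2 and a step that the two limits leave unreadable from compound 1 to compound 3 and a step that the two limits leave unreadable from compound 2 to compound 3 all bear on it. None of them has a readable size, so they give no measure of what this kind of change can do. The expectation rests on compound 3, whose limit of > 100000 nM leaves room only for a lower reported number. Estimated in numbers, the expected change is an at least 1.4-fold lower number from compound 3 to compound 4 (0.15 log units; that floor lies within the scatter) and it may stay unreadable if the new reading is also a limit. The estimated solubility of compound 4 is 70000 nM with an expected range from 20000 nM to 100000 nM and a fair chance of a limit instead of a number.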

Compound 4, solubility: 39000 nM
Compound 4: the middle estimate sits 1.8-fold (0.25 log units) above what was measured, and the stated range covers the measured number.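

In this assay this carbon now shows a change with a readable lower bound, with an at least 2.5-fold lower number from compound 3 to compound 4 (0.40 log units; beyond the scatter) and an at least 2.5-fold lower number from compound 2 to compound 4 (0.40 log units; beyond the scatter) and an at least 2.5-fold lower number from compound 1 to compound 4 (0.40 log units; beyond the scatter) on replacing 2-methylphenyl, 2-chlorophenyl and 4-methoxyphenyl in turn with 3,4-dichlorophenyl. Within the data shown here, the swaps among those three earlier groups cannot be read, so compound 4 is the first sign that the group at this carbon can bring the reading off the limit of the assay. The three steps are floors and not full sizes, because compound 1, compound 2 and compound 3 have no number of their own: the limit of > 100000 nM in this assay, at which 3 of the 4 values shown sit.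

The true size of the drop stays open, and so does the question of whether it needs both chlorines of 3,4-dichlorophenyl, since no compound shown separates them. Also open, on these data alone, is how this assay would read with an amine or a carboxylic acid on the phenyl ring at this carbon, or with a carboxylic acid in place of the ethoxycarbonyl group on the shared core.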